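Growing a Methyl into a Tert-Butyl on a Benzyl Ring

The source may report more compounds than this note shows. Statements on the series, on what has been measured and on what is new or still open speak of the compounds shown alone.

Measured so far:
Compound 1, `O=C(NO)c1ccc(CN(Cc2ccccc2)S(=O)(=O)c2c(F)c(F)c(F)c(F)c2F)cc1`, gives 9 nM in an assay on isolated protein for inhibition of protein deacetylase HDAC6 (Homo sapiens), read by mobility shift assay; a lower number here means a stronger inhibitor, a higher number a weaker inhibitor.
Compound 2, `Cc1ccc(CN(Cc2ccc(C(=O)NO)cc2)S(=O)(=O)c2c(F)c(F)c(F)c(F)c2F)cc1`, gives 6 nM in this assay.

On these two numbers compound 2 stands at one end, with compound 1 close by; the step of a 1.5-fold lower number from compound 1 to compound 2 (0.18 log units; within the scatter) separates them, and it lies within the scatter of repeated measurements.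

Compound 3, `CC(C)(C)c1ccc(CN(Cc2ccc(C(=O)NO)cc2)S(=O)(=O)c2c(F)c(F)c(F)c(F)c2F)cc1`, has not yet been measured. It differs from compound 2 by tert-butyl in place of methyl on an aromatic carbon. Among the measured compounds shown here, the only measured step that touches this position is a 1.5-fold lower number from compound 1 to compound 2 (0.18 log units; within the scatter), which was too small to count as a real change. Nothing measured tells how a larger group at the same place behaves, so the expectation rests on that single step alone.

Compound 3 is therefore expected to give about 6 nM in this assay, with a plausible range from 3 nM to 15 nM. This amounts to an expected step of no change at the digits printed from compound 2 to compound 3 (within the scatter), not beyond the scatter.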

Compound 3, half-maximal inhibitory concentration: 42 nM
For compound 3 the middle estimate is 7.0-fold (0.85 log units) below the measured one, and the stated range ends below it.
By their numbers in this assay, from the lowest: compounds 2 and 1 (each within the scatter of the next); then compound 3.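

This position on the benzyl ring is not indifferent to what it carries: in this assay the change shows as a 7.0-fold higher number from compound 2 to compound 3 (0.85 log units; beyond the scatter) and so goes beyond the scatter, while the methyl stayed within the scatter of plain hydrogen. The comparison with the unsubstituted ring points the same way, with a 4.7-fold higher number from compound 1 to compound 3 (0.67 log units; beyond the scatter), so a group of 1 heavy atom leaves the number in place and one of 4 heavy atoms does not. Nothing measured here explains why the number rises.

As far as these compounds go, whether ethyl or isopropyl would stay close to methyl or already move toward tert-butyl remains open, so the size at which the number starts to climb is unknown. Also open, from the compounds shown here alone, is how a different kind of group here, such as a methoxy, an amine or a carboxylic acid, would behave.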